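Replacing a hydroxypropyl side chain with a hydroxycyclohexyl ring

This account rests on a few compounds, and the source may have more. Where it says the series, first, only, none or still open, it means among the compounds named here.

Measured so far in an assay on isolated protein for binding affinity to adenosine receptor A1 (Bos taurus); on this read-out higher numbers stand for weaker inhibition and lower numbers for stronger inhibition:
compound 1 `CC(O)CNc1nc(-c2ccccc2)nc2c1nnn2Cc1ccccc1Cl` gives 32000000 nM.
compound 2 `FC(F)(F)c1ccccc1Cn1nnc2c(NC3CCCCC3)nc(-c3ccccc3)nc21` gives 6800000 nM.
compound 3 `CC(O)CNc1nc(-c2ccccc2)nc2c1nnn2Cc1ccccc1F` gives 4800000 nM.

Compound 1 stands highest of these three numbers. Compound 4 `OC1CCC(Nc2nc(-c3ccccc3)nc3c2nnn3Cc2ccccc2Cl)CC1` differs from it by one change: 4-hydroxycyclohexyl in place of 2-hydroxypropyl on a nitrogen on an aromatic ring. Going by the values given here, no measured step changes this same position. Among the compounds with values here, the only single-point step, a 6.7-fold lower number from compound 1 to compound 3 (0.82 log units; beyond the scatter), concerns the halogen elsewhere and says little here. Compound 2 carries a ring on the same nitrogen but also a different halogen group, so its lower number can only hint that a ring on the nitrogen may be tolerated. Compound 4 is therefore expected to give a modestly lower number, a 2.7-fold lower number from compound 1 to compound 4 (0.43 log units; beyond the scatter), estimated at 12000000 nM with a range from 2500000 nM to 60000000 nM.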

Compound 4, inhibition constant: 3100000 nM
Compound 4: middle estimate off by 3.9-fold (0.59 log units), on the high side; the measured number falls inside the stated range.
By their numbers in this assay, from the lowest: compounds 4, 3 and 2 (each within the scatter of the next, the first and the last beyond it); then compound 1.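

The nitrogen position now has its first direct reading: in this assay, the switch to 4-hydroxycyclohexyl gives a 10-fold lower number from compound 1 to compound 4 (1.01 log units; beyond the scatter), a large step. This shows that the group on this nitrogen matters and that a larger group with a six-membered ring is accepted on the core of compound 1, with the number moving towards stronger inhibition. No data shown explain this change. Still open, going by these compounds, is whether the ring's hydroxyl is needed, or whether an amine or a carboxylic acid in its place would give a similar number. On these data alone, whether the same step holds on the fluoro core of compound 3 also remains open.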